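A few compounds are considered here, and "the series" means these few. Any claim that something is new, unique, unknown or untested is made for them only; others in the source may bear on it.

Compound 1 `Fc1ccc(-n2cc(COc3ccccc3-c3nc4ccccc4s3)nn2)cc1Cl` gives 16300 nM in a functional assay on A549 cells (Homo sapiens) for cytotoxicity, read by MTT assay, with a stated time of 24 h; on this read-out lower numbers stand for stronger inhibition and higher numbers for weaker inhibition.
Compound 2 `FC(F)(F)Oc1ccc(-c2cc(COc3ccccc3-c3nc4ccccc4s3)on2)cc1` gives 23900 nM in this assay.
Compound 3 `COc1ccc(-c2nc3cc(F)ccc3s2)cc1OC` gives 15900 nM in this assay.

On these three numbers compound 1 stands second highest, but the spread is narrow: its nearest neighbour is compound 3, whose number differs from it by a margin within the usual scatter, and even compound 2, the furthest of the three, lies within the scatter of compound 1. Going by the values given here, no two of the measured compounds differ in only one place, so no single step in this assay can be read from them.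

The unmeasured compound is compound 4 `c1ccc(-n2cc(COc3ccccc3-c3nc4ccccc4s3)nn2)cc1`. It differs from compound 1 by phenyl in place of 3-chloro-4-fluorophenyl on an aromatic nitrogen. Among the compounds with values here, nothing among the measured compounds shows what this change does in this assay. Within the data shown here, with no comparable step to draw on, the step from a 1.3-fold higher number from compound 1 to compound 4 (0.11 log units; within the scatter) is expected to be small, a slight rise if anything, and not beyond the scatter. Compound 4 is therefore estimated at 21000 nM in this assay, with an expected range from 9000 nM to 50000 nM.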

Compound 4, half-maximal inhibitory concentration: 16400 nM
Compound 4: the middle estimate sits 1.3-fold (0.11 log units) above what was measured, within the range that was stated.
By their numbers in this assay, from the lowest: compounds 3, 1, 4 and 2 (each within the scatter of the next).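

In this assay, the replacement of 3-chloro-4-fluorophenyl by phenyl on the aromatic nitrogen gives a 1.0-fold higher number from compound 1 to compound 4 (0.00 log units; within the scatter), the first step among these compounds that can be read at all. At this position, then, the loss of the chlorine and the fluorine leaves no readable mark on the number, and the unsubstituted phenyl serves as well as the halogenated ring in this assay. Nothing available here accounts for this result.

Going by these compounds alone, this single step compares only two aryl groups, so it leaves open how a different kind of group on the same nitrogen, such as an aminomethyl group, a carboxylic acid or a longer alkyl chain, would read. The compounds shown also leave open whether the same replacement would come out alike on another core.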